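The compounds below may be only part of what the source reports. "The series", "measured", "known", "first", "only" and "open" are said of these compounds alone.

Measured so far:
compound 1 `Cc1ccc([C@@H]2CN(C)[C@]3(C(=O)Nc4ccccc43)[C@]23Cc2ccccc2C3=O)cc1` — 23.8%
compound 2 `Cc1ccc([C@@H]2CN(C)[C@]3(C(=O)N(C)c4ccccc43)[C@]23Cc2ccccc2C3=O)cc1` — 8%
compound 3 `COc1ccc([C@@H]2CN(C)[C@]3(C(=O)N(C)c4ccccc43)[C@]23Cc2ccccc2C3=O)cc1` — 20.2%

In a functional assay on the whole organism (strain Wister albino) for inhibition, with Rattus norvegicus as the target, read by paw edema, with stated times of 1 h and 2 h, at a dose of 50 mg/kg by the intraperitoneal route (a higher number here means more inhibition at the dose given (going by the name of the read-out), a lower number less inhibition), compound 1 gives 23.8%, compound 2 gives 8%, and compound 3 gives 20.2%. Two single changes connect them. One is hydrogen in place of methyl on an amide-type nitrogen in a ring, which made the step of a number 15.8 percentage points higher from compound 2 to compound 1 (beyond the scatter). The other is methoxy in place of methyl on an aromatic carbon, which made the step of a number 12.2 percentage points higher from compound 2 to compound 3 (beyond the scatter). Compound 1 and compound 3 lie within the scatter of each other.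

Compound 4 `COc1ccc([C@@H]2CN(C)[C@]3(C(=O)Nc4ccccc43)[C@]23Cc2ccccc2C3=O)cc1` has not been measured in this assay. It differs from compound 3 by hydrogen in place of methyl on an amide-type nitrogen in a ring, the same change as between compound 2 and compound 1, at the same place; the two cores differ by methoxy in place of methyl on an aromatic carbon. Because the earlier step was a number 15.8 percentage points higher from compound 2 to compound 1 (beyond the scatter), a step of similar direction is expected, a number 13.8 percentage points higher from compound 3 to compound 4 (beyond the scatter), from compound 3 to compound 4. Compound 4 is therefore expected to give about 34%, most plausibly between 22% and 46%.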

Compound 4, a percentage reported as inhibition, in the whole organism at one dose (the size of the read-out at that dose, not a potency): 17.5%
Beside the measured number, compound 4's estimate is 16.5 percentage points above it; measured number below the stated range.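

In this assay, hydrogen in place of methyl on the amide-type nitrogen gave a number 2.7 percentage points lower from compound 3 to compound 4 (within the scatter), so this change did not carry over from one core to the other: the same change on two cores in this assay, a number 15.8 percentage points higher (beyond the scatter) from compound 2 to compound 1 and a number 2.7 percentage points lower (within the scatter) from compound 3 to compound 4, 18.5 percentage points apart, beyond the scatter of two such steps

Methoxy in place of methyl on the aromatic carbon gave a number 6.3 percentage points lower from compound 1 to compound 4 (within the scatter), and this change did not carry over either: the same change on two cores in this assay, a number 12.2 percentage points higher (beyond the scatter) from compound 2 to compound 3 and a number 6.3 percentage points lower (within the scatter) from compound 1 to compound 4, 18.5 percentage points apart, beyond the scatter of two such steps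

The four compounds show that, at this one dose, the two changes do not simply add, but they do not show why, or whether this holds beyond these compounds.

The compounds shown leave open how the inhibition responds to other groups on the aromatic carbon, such as chlorine or hydroxyl. They also leave open what an ethyl or a longer chain would do on the amide-type nitrogen.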